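Isopropyl Added Beside the Acid: Expected Potency

The source may hold more compounds than are shown below. What is called first, only, known or untested is meant among the compounds shown, and "the series" means these compounds.

Compound 1 `CC(C)(C)C1=CC(=O)C=C(NCC(=O)O)C1=O`: 171000 nM
Compound 2 `CC1=CCC[C@H]2[C@](C)(CC3=CC(=O)C=C(NCC(=O)O)C3=O)[C@@H](C)CC[C@]12C`: 5840 nM
Compound 3 `CC(C)[C@@H](NC1=CC(=O)C=C(C(C)(C)C)C1=O)C(=O)O`: 133000 nM

All three were tested in a functional assay on MDA-MB-453 cells (Homo sapiens) for cytotoxicity, read by MTT assay, with a stated time of 72 h; a higher number here means a weaker inhibitor, a lower number a stronger inhibitor. Compound 1 and compound 3 share a core and differ by a single change, (isopropyl in place of hydrogen on a saturated chain carbon bound to an amine nitrogen and a carbonyl carbon), which gave a 1.3-fold lower number from compound 1 to compound 3 (0.11 log units; within the scatter). Compound 2 carries a different, larger core; the difference between the two cores is not broken down here. In this assay compound 2 gives the lowest number of the three, and its steps to compound 1 and to compound 3 are both beyond the scatter.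

Compound 4 `CC1=CCC[C@H]2[C@](C)(CC3=CC(=O)C=C(N[C@@H](C(=O)O)C(C)C)C3=O)[C@@H](C)CC[C@]12C` is not yet measured. It differs from compound 2 by isopropyl in place of hydrogen on a saturated chain carbon bound to an amine nitrogen and a carbonyl carbon, the same change that was made from compound 1 to compound 3, at the same place. Because that change produced a 1.3-fold lower number from compound 1 to compound 3 (0.11 log units; within the scatter), the expected step on the core of compound 2 is likewise small, estimated at a 1.2-fold lower number from compound 2 to compound 4 (0.09 log units; within the scatter). Compound 4 is therefore expected to fall near compound 2, with an estimate of 4800 nM and a likely range from 2000 nM to 12000 nM.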

Compound 4, half-maximal inhibitory concentration: 8010 nM
Beside the measured number, compound 4's estimate is 1.7-fold (0.22 log units) below it; low and high end bracket the measured number.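

In this assay the isopropyl group gave a 1.4-fold higher number from compound 2 to compound 4 (0.14 log units; within the scatter) and that step is a small one. It does not prove that the change has no effect at all: a small real shift could still hide inside the scatter, and two cores cannot speak for the whole series. What these four compounds do show is that the change carried from one core to the other, with the two steps not distinguishable from each other: the same change on two cores in this assay, a 1.3-fold lower number (0.11 log units; within the scatter) from compound 1 to compound 3 and a 1.4-fold higher number (0.14 log units; within the scatter) from compound 2 to compound 4, 1.8-fold (0.25 log units) apart, within the scatter of two such steps

The compounds shown leave open what other groups would do on the saturated chain carbon bound to an amine nitrogen and a carbonyl carbon, such as a longer chain, a phenyl ring or a hydroxymethyl group. They also leave open whether an amide or an ester in place of the carboxylic acid would change the number, and whether the same small step would hold on a third core.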